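The source may report more compounds than this note shows. Statements on the series, on what has been measured and on what is new or still open speak of the compounds shown alone.

Working notes on the series.

Two compounds in this series carry a number in a functional assay on NIH3T3 cells (Mus musculus) for inhibition, tested at 10 uM; a lower number here means less inhibition, a higher number more inhibition at the concentration tested (going by the name of the read-out). Compound 1, `Oc1ccccc1C(O)(c1ccccc1)c1ccccc1`, gives 99%; 99% (2 entries) in this assay, two entries that agree. Compound 2, `OC(c1ccccc1)(c1ccccc1)c1ccc(C(F)(F)F)cc1`, gives 98% in this assay; a further entry for compound 2 exists but yields no single number. The two values of compound 1 and compound 2 lie within the scatter of each other, so no order between them can be read. Both sit close to the top of the inhibition scale at the test concentration, which leaves little room upward for any change.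

Compound 3, `OC(c1ccccc1)(c1ccccc1)c1ccc(Cl)cc1`, is not yet measured. It differs from compound 2 in one place: chloro in place of trifluoromethyl on an aromatic carbon. Among the compounds with values here, no step between measured compounds bears on this kind of change, so the expectation rests on the standing of compound 2 alone. Because compound 2 gives 98%, the step from compound 2 to compound 3 is expected to be no more than the scatter, a number 2 percentage points lower from compound 2 to compound 3 (within the scatter), with the only real freedom downward. Compound 3 is expected to give 96% in this assay, with a range from 84% to 100%.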

Compound 3, a percentage reported as inhibition, at one concentration (the size of the read-out at that concentration, not a potency): 99%
For compound 3 the middle estimate is 3 percentage points below the measured one; low and high end bracket the measured number.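

In this assay, within the data shown here, chloro in place of trifluoromethyl on an aromatic carbon, para to a large group, gives a number 1 percentage points higher from compound 2 to compound 3 (within the scatter), the first step that can be read between two measured compounds. This position therefore accepts the exchange of trifluoromethyl for chloro, a group with fewer heavy atoms, without a change beyond the scatter, and the inhibition stays close to the top of the scale at the test concentration. No measurement at hand explains this result or links it to a property of either group.

With compound 2 and compound 3 both so close to the top of the scale, a read-out at one concentration cannot show whether the two differ in potency, so any difference between them stays unresolved. It also stays open whether the inhibition holds with an amine, a carboxylic acid or a longer alkyl chain at this same aromatic carbon, since only trifluoromethyl and chloro are shown there.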